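Amine exchange on the shared core: compound 2 to compound 3

The source may report more compounds than this note shows. Statements on the series, on what has been measured and on what is new or still open speak of the compounds shown alone.

Measured in a functional assay on MIA PaCa-2 cells (Homo sapiens) for inhibition, read by MTT assay, with a stated time of 48 h, tested at 10 uM (on this read-out higher numbers stand for more inhibition of growth at the one concentration tested and lower numbers for less inhibition of growth), so far:
- compound 1 `Cc1cc(=O)c2c(O)c(CN3CCC(c4ccccc4)CC3)c(O)c([C@H]3CCN(C)C[C@H]3O)c2o1` gives 16%
- compound 2 `Cc1cc(=O)c2c(O)c(CN(C(C)C)C(C)C)c(O)c([C@H]3CCN(C)C[C@H]3O)c2o1` gives 11%

Compound 2 stands within the scatter of compound 1, so this assay does not separate the two. Compound 3 `Cc1cc(=O)c2c(O)c(CN3CCCCC3)c(O)c([C@H]3CCN(C)C[C@H]3O)c2o1` carries piperidin-1-yl in place of diisopropylamino on a saturated chain carbon bound to an aromatic carbon, with piperidin-1-yl in place of diisopropylamino on a saturated chain carbon bound to an aromatic carbon. Within the data shown here, no measured step covers this change. With compound 1 at 16% and compound 2 at 11%, no step beyond the scatter is expected in this assay, in either direction. The estimated a number 3 percentage points higher from compound 2 to compound 3 (within the scatter) stays within the scatter. For compound 3 the expected value is 14%, with an estimated range from 4% to 28%.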

Compound 3, percent growth inhibition at one concentration: 14%
For compound 3 middle estimate and measured number coincide at the digits printed; measured number inside the range.
By their numbers in this assay, from the lowest: compounds 2, 3 and 1 (each within the scatter of the next).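

In this assay, piperidin-1-yl in place of diisopropylamino on a saturated chain carbon bound to an aromatic carbon gives a step within the scatter (a number 3 percentage points higher from compound 2 to compound 3 (within the scatter)). Hydrogen in place of phenyl on a saturated ring carbon also stays within the scatter (a number 2 percentage points lower from compound 1 to compound 3 (within the scatter)), so neither the open-chain amine nor the phenyl substituent is separated from the plain piperidin-1-yl group on this read-out. No measured evidence bears on why these amines read alike.

From the compounds shown here alone, whether morpholin-4-yl, a primary amine or a carboxylic acid on the same carbon would separate from these values remains open. So does whether these three compounds separate at any other concentration.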